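The source may report more compounds than this note shows. Statements on the series, on what has been measured and on what is new or still open speak of the compounds shown alone.

Measured compounds in the series:

compound 1, `Cc1ccc(-c2cc(CC(=O)c3c(O)cc(O)cc3O)n[nH]2)cc1` — 49000 nM
compound 2, `CN(C)CCNC(=O)c1ccccc1Sc1ccccc1Cl` — limit, > 50000 nM
compound 3, `CN(C)CCNCc1ccccc1Sc1ccccc1` — limit, > 50000 nM

All three were tested in an assay for inhibition of protein arginine N-methyltransferase 1 (Rattus norvegicus), read by scintillation counting, with stated times of 15 min and 60 min, in the presence of a further agent that is not named here; a higher number here means a weaker inhibitor, a lower number a stronger inhibitor. Compound 1 gives 49000 nM in this assay. For compound 2 this assay reports only a limit, > 50000 nM. For compound 3 this assay likewise reports only a limit, > 50000 nM, so compound 3 has no number of its own, and one further compound shares that position: the limit of > 50000 nM in this assay, at which 2 of the 3 values shown sit. Compound 3 therefore stands at the weak end of what this assay can resolve, with no ordering possible against compound 2.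

The next compound, compound 4, `CN(C)CCNCc1ccccc1Sc1ccccc1Cl`, differs from compound 3 in one place: chloro in place of hydrogen on an aromatic carbon, ortho to a large group, so that phenyl becomes 2-chlorophenyl. Among the compounds with values here, no measured step of this kind exists among the compounds above. Compound 2 carries a 2-chlorophenyl of the same kind and also sits at the limit. On that basis the step from compound 3 to compound 4 is expected to be a number no higher from compound 3 to compound 4 (the limit leaves the size open), nothing beyond the scatter. Compound 4 is accordingly estimated at 50000 nM in this assay, within 15000 nM to 150000 nM, most likely reported again as a limit.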

Compound 4, half-maximal inhibitory concentration: 54000 nM
Estimate against measurement, compound 4: 1.1-fold (0.03 log units) below; the measured number falls inside the stated range.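

Compound 3 has only a limit in this assay, > 50000 nM, and no number of its own. Within the data shown here, no step from compound 3 to compound 4 can therefore be read, with compound 4 at 54000 nM: the limit of > 50000 nM in this assay, at which 2 of the 4 values shown sit. The compounds shown leave open whether chloro in place of hydrogen on an aromatic carbon changes inhibition in this series at all.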